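The source may report more compounds than this note shows. Statements on the series, on what has been measured and on what is new or still open speak of the compounds shown alone.

Measured compounds:

compound 1, `CCCCCCCCCCc1cc2cn(COCCO)c(O)nc-2n1` — 80000 nM
compound 2, `CCCCCCCC#Cc1cc2cn(COCCO)c(=O)nc2o1` — 200000 nM
compound 3, `CCCCCCCCCCCc1cc2cn(COCCO)c(O)nc-2n1` — 80000 nM

All three were read in a functional assay on HEL cells (Homo sapiens), read by microscopy; on this read-out lower numbers stand for higher toxicity in this test and higher numbers for lower toxicity in this test. Compound 1 and compound 3 share a core and differ by methyl in place of hydrogen on a saturated chain carbon, ten or more bonds along the chain from an aromatic carbon; this step, no change at the digits printed from compound 1 to compound 3 (within the scatter), leaves the read-out as it was. Compound 2 carries a different core; the difference between the two cores is not broken down here. In this assay compound 2 gives the highest of the three numbers, and its distance from compound 1 and from compound 3 is beyond the scatter in both cases.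

Compound 4, `CCCCCCCCC#Cc1cc2cn(COCCO)c(=O)nc2o1`, is the untested member. Relative to compound 2 it shows (methyl in place of hydrogen on a saturated chain carbon, seven bonds along the chain from a triple-bonded carbon). Among the compounds with values here, this is the same kind of change as the one from compound 1 to compound 3, but the surroundings differ: there the added methyl sits on a saturated chain carbon counted from an aromatic carbon, here on a saturated chain carbon counted from a triple-bonded carbon. Within the data shown here, the only precedent, no change at the digits printed from compound 1 to compound 3 (within the scatter), was flat, so the expected step in this assay is no change at the digits printed from compound 2 to compound 4 (within the scatter), resting on that one pair. Compound 4 is accordingly estimated at 200000 nM, with a range from 100000 nM to 400000 nM.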

Compound 4, minimum cytotoxic concentration: >= 20000 nM
Compound 4 was reported as a limit; the forecaster's own chance of this, stated with the estimate: 20%; the middle value does not contradict the limit.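

In this assay compound 4 gives >= 20000 nM, which is a limit of the assay and not a number. No step can be read between compound 2 and compound 4, because only a limit stands on one side: the limit of >= 20000 nM in this assay, at which 1 of the 4 values shown sits. From the compounds shown here alone, whether methyl in place of hydrogen at this place changes the read-out on the core of compound 2 stays open.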